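This account rests on a few compounds, and the source may have more. Where it says the series, first, only, none or still open, it means among the compounds named here.

Three compounds share one core and differ only in the amine at the end of a chain that hangs from an oxygen on an aromatic ring. Compound 1 `CCN(CC)CCCOc1c(OCc2ccccc2)cc(O)c2c(=O)cc(-c3ccccc3)oc12` in a functional assay on MCF7 cells (Homo sapiens) for cytotoxicity, read by MTT assay, with a stated time of 72 h (on this read-out higher numbers stand for weaker inhibition and lower numbers for stronger inhibition), gives 3210 nM. Compound 2 `O=c1cc(-c2ccccc2)oc2c(OCCCN3CCCC3)c(OCc3ccccc3)cc(O)c12` gives 2230 nM in this assay, and compound 3 `CCN(CC)CCCCOc1c(OCc2ccccc2)cc(O)c2c(=O)cc(-c3ccccc3)oc12` gives 1920 nM. Compound 3 has the lowest number of the three, but the step of a 1.2-fold lower number from compound 2 to compound 3 (0.07 log units; within the scatter) and the step of a 1.7-fold lower number from compound 1 to compound 3 (0.22 log units; within the scatter) are both within the scatter, so no order among the three can be claimed.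

Compound 4 `O=c1cc(-c2ccccc2)oc2c(OCCCCN3CCCC3)c(OCc3ccccc3)cc(O)c12` has not yet been measured in this assay. Compared with compound 3, the change is pyrrolidin-1-yl in place of diethylamino on a saturated chain carbon, four bonds along the chain from an oxygen on an aromatic ring. The same swap has been seen once before, one bond closer to the ring, as the step of a 1.4-fold lower number from compound 1 to compound 2 (0.16 log units; within the scatter). That step was small, and the step of a 1.2-fold lower number from compound 2 to compound 3 (0.07 log units; within the scatter), which also touches these amines, was smaller still. Nothing in these numbers points to a step beyond the scatter.

The expectation for compound 4 in this assay is therefore 1500 nM, within a range from 700 nM to 3500 nM. The expected step from compound 3 is a 1.3-fold lower number from compound 3 to compound 4 (0.11 log units; within the scatter), a move not beyond the scatter.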

Compound 4, half-maximal inhibitory concentration: 1890 nM
The estimate for compound 4 lay 1.3-fold (0.10 log units) below the measured number, and the stated range covers the measured number.
By their numbers in this assay, from the lowest: compounds 4, 3, 2 and 1 (each within the scatter of the next).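

At this place, four bonds along the chain from an oxygen on an aromatic ring, exchanging diethylamino for pyrrolidin-1-yl, an open amine for a five-membered ring with the same heavy atoms, leaves no readable difference in this assay (a 1.0-fold lower number from compound 3 to compound 4 (0.01 log units; within the scatter)). Until now this swap had been read on the shorter chain only, and the second reading shows that the small step seen there also holds on the longer chain, so the two agree: the same change on two cores in this assay, a 1.4-fold lower number (0.16 log units; within the scatter) from compound 1 to compound 2 and a 1.0-fold lower number (0.01 log units; within the scatter) from compound 3 to compound 4, 1.4-fold (0.15 log units) apart, within the scatter of two such steps. Lengthening the chain while keeping the pyrrolidine gives no readable difference either (a 1.2-fold lower number from compound 2 to compound 4 (0.07 log units; within the scatter)), and changing the amine and the chain together also stays within what repeated measurements would scatter (a 1.7-fold lower number from compound 1 to compound 4 (0.23 log units; within the scatter)).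

On these data alone, all four compounds end in one of only two amines on one of two chain lengths, so it remains open whether a piperidine, a morpholine or a much longer chain would move the number beyond the scatter. As far as these compounds go, it is also open whether a carboxylic acid or a simple hydroxyl group at the end of the chain, in place of the amine, would do so.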